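The compounds below may be only part of what the source reports. "The series", "measured", "known", "first", "only" and "open" are said of these compounds alone.

Compound 1 `Cc1c(Cc2cccnc2)cc2c(c1CCC(=O)O)CCC(NS(=O)(=O)c1ccc(Cl)cc1)C2`: 610 nM
Compound 2 `O=C(O)CCC/C=C/c1cc(Cc2cccnc2)cc2c1CCC(NS(=O)(=O)c1ccc(Cl)cc1)C2`: 1200 nM

Both compounds were tested in a functional assay for inhibition, with Homo sapiens as the target; a lower number here means a stronger inhibitor, a higher number a weaker inhibitor. There, compound 2 gives 1200 nM, which lies within the usual scatter of compound 1, so the two numbers cannot be told apart.

Compound 3 `Cc1c(Cc2cccnc2)cc2c(c1/C=C/CCCC(=O)O)CCC(NS(=O)(=O)c1ccc(Cl)cc1)C2` differs from compound 2 by one change: methyl in place of hydrogen on an aromatic carbon. The new methyl is ortho to a (pyridin-3-yl)methyl group and ortho to a 5-carboxypent-1-en-1-yl group.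

Going by the values given here, no measured pair shows this change alone. A small move toward a lower number is expected, probably no larger than the scatter, because compound 1 with the same methyl but a different acid chain gives 610 nM. The expected change is a 1.6-fold lower number from compound 2 to compound 3 (0.20 log units; within the scatter). In this assay the estimate for compound 3 is 750 nM, with an expected range from 250 nM to 2200 nM.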

Compound 3, half-maximal inhibitory concentration: 460 nM
For compound 3 the middle estimate is 1.6-fold (0.21 log units) above the measured one, and the stated range covers the measured number.
By their numbers in this assay, from the lowest: compounds 3, 1 and 2 (each within the scatter of the next, the first and the last beyond it).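

In this assay, methyl in place of hydrogen on the aromatic carbon ortho to a (pyridin-3-yl)methyl group and ortho to a 5-carboxypent-1-en-1-yl group gives a 2.6-fold lower number from compound 2 to compound 3 (0.42 log units; beyond the scatter), a modest step that isolates this methyl and lies beyond the scatter. With the methyl kept, 5-carboxypent-1-en-1-yl in place of 2-carboxyethyl gives a 1.3-fold lower number from compound 1 to compound 3 (0.12 log units; within the scatter), so these two acid chains cannot be told apart here. Nothing available gives a reason for the methyl's step.

Open, as far as these compounds go, is whether an ethyl group or a chlorine atom on this carbon would move the number as the methyl does. Also open, from the compounds shown here alone, is how an amide in place of the carboxylic acid would read on either chain.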